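Ester Chain Extension on an Inactive Aldehyde Series

The source may report more compounds than this note shows. Statements on the series, on what has been measured and on what is new or still open speak of the compounds shown alone.

Measured in a functional assay on A549 cells (Homo sapiens) for inhibition, read by MTT assay, with a stated time of 72 h (on this read-out lower numbers stand for stronger inhibition of growth and higher numbers for weaker inhibition of growth), so far

- compound 1 `CCOC(=O)/C=C/C1=CC[C@H]2C(C)(C)CCC[C@]2(C)[C@H]1C=O` gives 25000 nM
- compound 2 `CC1(C)CCC[C@]2(C)[C@@H](C=O)C(/C=C/C(=O)OCc3ccccc3)=CC[C@@H]12` gives 28000 nM
- compound 3 `CC1(C)CCC[C@]2(C)[C@@H](C=O)C(/C=C/C#N)=CC[C@@H]12` gives 27000 nM

Compound 1 stands level with compound 2 and compound 3, as both steps away from it lie within the scatter. Compound 4 `C#CCCCOC(=O)/C=C/C1=CC[C@H]2C(C)(C)CCC[C@]2(C)[C@H]1C=O` has not yet been measured. It keeps the core of compound 1 and differs only in the ester group, by propargyl in place of hydrogen on a saturated chain carbon, two bonds along the chain from an oxygen next to a carbonyl group in all. This is propargyl in place of hydrogen on a saturated chain carbon, two bonds along the chain from an oxygen next to a carbonyl group, so ethoxy becomes (pent-4-yn-1-yl)oxy.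

Among the compounds with values here, two measured steps bear on this change. Compound 2 alters the same ester group, with phenyl in place of methyl, and the result is a 1.1-fold higher number from compound 1 to compound 2 (0.05 log units; within the scatter) in this comparison. Compound 3 replaces the whole ethoxycarbonyl with cyano, and the result is a 1.1-fold higher number from compound 1 to compound 3 (0.03 log units; within the scatter) in this comparison. No chain with a triple bond has been measured, so this evidence is indirect. Even so, no step beyond the scatter is expected in this assay in either direction. The expected step is a 1.0-fold higher number from compound 1 to compound 4 (0.02 log units; within the scatter) by this estimate. Compound 4 is expected at 26000 nM with an estimated range from 14000 nM to 45000 nM in this assay.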

Compound 4, concentration for 50% growth inhibition: 30000 nM
The estimate for compound 4 lay 1.2-fold (0.06 log units) below the measured number; low and high end bracket the measured number.
By their numbers in this assay, from the lowest: compounds 1, 3, 2 and 4 (each within the scatter of the next).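

In this assay, adding propargyl on a saturated chain carbon, two bonds along the chain from an oxygen next to a carbonyl group, gives a 1.2-fold higher number from compound 1 to compound 4 (0.08 log units; within the scatter), so this ester group takes a chain ending in a triple bond without any step beyond the scatter. The new chain also stands level with the other two replacements, with a 1.1-fold higher number from compound 2 to compound 4 (0.03 log units; within the scatter) against the phenyl-bearing ester and a 1.1-fold higher number from compound 3 to compound 4 (0.05 log units; within the scatter) against the cyano compound. With this third change, all four compounds lie within the scatter of each other, and neither a longer chain with a triple bond, a phenyl-bearing ester nor cyano separates from the ethyl ester in this series.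

The compounds shown leave open whether any group at this place can move the number at all, for instance a carboxylic acid or an amine-bearing chain in place of the ester, and whether a change to the aldehyde on the shared core, such as a hydroxymethyl group, would matter more. Nothing available here explains why the numbers stay level across these four compounds.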